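The source may hold more compounds than are shown below. What is called first, only, known or untested is meant among the compounds shown, and "the series" means these compounds.

Measured so far in an assay on isolated protein for inhibition of Amine oxidase [flavin-containing] B (Homo sapiens); on this read-out lower numbers stand for stronger inhibition and higher numbers for weaker inhibition:

- compound 1, `CCOc1ccc(C(=O)/C=C/c2ccc(C)cc2)cc1`: 210 nM
- compound 2, `O=C(/C=C/c1ccccc1F)c1ccc(-n2ccnc2)cc1`: a limit, > 10000 nM
- compound 3, `O=C(/C=C/c1ccc(ON=C2CCCCC2)cc1)c1ccc(F)cc1`: a limit, < 50 nM

Compound 3 sits at the strong end of what this assay reports. Its value is a limit, not a number: compound 3 gives < 50 nM in this assay, and the limit of < 50 nM in this assay, at which 1 of the 3 values shown sits, is where it rests. Compound 2 likewise gives only a limit, > 10000 nM, the point described by the limit of > 10000 nM in this assay, at which 1 of the 3 values shown sits. Compound 1 is the only one of the three with a number, 210 nM in this assay. No two of these compounds differ in a single place, so none of the gaps between them can be read as a step.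

The next compound, compound 4, is `CC/C(C)=N/Oc1ccc(/C=C/C(=O)c2ccc(F)cc2)cc1`. It differs from compound 3 in one place: a group of 5 heavy atoms (4 carbon, 1 nitrogen; no ring) in place of a group of 7 heavy atoms (6 carbon, 1 nitrogen; one six-membered non-aromatic ring of carbon only), on an oxygen on an aromatic ring. The group that enters is open where the one that leaves held a six-membered non-aromatic ring; both keep one acceptor and one double bond outside aromatic rings.

Without a measured step to lean on, the account expects the step from compound 3 to compound 4 to be small, an at least 1.4-fold higher number from compound 3 to compound 4 (0.14 log units; that floor lies within the scatter), at most a modest loss. Compound 4 is expected to reach about 70 nM in this assay, within 20 nM to 300 nM.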

Compound 4, half-maximal inhibitory concentration: 28 nM
Compound 4: middle estimate off by 2.5-fold (0.40 log units), on the high side, and the stated range covers the measured number.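

For the compounds shown here, compound 3 rests on a limit in this assay, so no step from it to compound 4 can be read: the limit of < 50 nM in this assay, at which 1 of the 4 values shown sits. The compounds shown leave open whether the open group of compound 4 and the six-membered non-aromatic ring of compound 3 differ at all in this assay, and if they do, by how much.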